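The source may hold more compounds than are shown below. What is called first, only, known or untested is meant among the compounds shown, and "the series" means these compounds.

In a functional assay on Z-138 cells (Homo sapiens) for antiproliferative activity, with a stated time of 72 h (on this read-out higher numbers stand for weaker inhibition and lower numbers for stronger inhibition), the measured compounds are:

Compound 1, `CCCC#Cc1cc([C@@H]2O[C@H](CO)[C@@H](O)[C@H]2O)n2ncnc(N)c12`, gives 20 nM.
Compound 2, `Nc1ncnn2c([C@@H]3O[C@H](CO)[C@@H](O)[C@H]3O)cc(-c3ccccc3)c12`, gives > 100000 nM; this is a limit of the assay rather than a number.
Compound 3, `Nc1ncnn2c([C@@H]3O[C@H](CO)[C@@H](O)[C@H]3O)cc(-c3ccc(Cl)cc3)c12`, gives 40200 nM.

Among the values that are numbers, compound 3 stands highest, meaning weakest; its nearest neighbour is compound 1, separated by a 2000-fold higher number from compound 1 to compound 3 (3.30 log units; beyond the scatter). Compound 4, `Nc1ncnn2c([C@@H]3O[C@H](CO)[C@@H](O)[C@H]3O)cc(-c3ccsc3)c12`, differs from compound 3 in one place: thiophen-3-yl in place of 4-chlorophenyl on an aromatic carbon. Among the compounds with values here, two measured steps bear on this change. Exchanging the pent-1-yn-1-yl chain for a six-membered aromatic ring gave a 2000-fold higher number from compound 1 to compound 3 (3.30 log units; beyond the scatter), and adding the chloro to that ring gave an at least 2.4-fold lower number from compound 2 to compound 3 (0.39 log units; beyond the scatter). Compound 4 keeps an aromatic ring in this position but has no chloro, so the expectation is a number around that of compound 3 or somewhat higher, with a real chance that only a limit is reported. Compound 4 is therefore expected to give about 80000 nM, within a range of 20000 nM to 300000 nM. This corresponds to an expected step of a 2.0-fold higher number from compound 3 to compound 4 (0.30 log units; within the scatter).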

Compound 4, half-maximal inhibitory concentration: 43500 nM
Estimate against measurement, compound 4: 1.8-fold (0.26 log units) above, and the stated range covers the measured number.
By their numbers in this assay, from the lowest: compound 1; then compounds 3 and 4 (each within the scatter of the next). At a limit, above all of these: compound 2.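

A five-membered aromatic ring with sulfur reads the same as the six-membered 4-chlorophenyl ring at this position: a 1.1-fold higher number from compound 3 to compound 4 (0.03 log units; within the scatter). The large gap to the pent-1-yn-1-yl chain is therefore not tied to one ring size, since it is just as wide with thiophen-3-yl: a 2200-fold higher number from compound 1 to compound 4 (3.34 log units; beyond the scatter). Against phenyl, thiophen-3-yl gives an at least 2.2-fold lower number from compound 2 to compound 4 (0.36 log units; beyond the scatter), a step that starts from a limit of the assay rather than a number and so marks only a minimum.

Still open, as far as these compounds go, is whether the triple bond or the length of the pent-1-yn-1-yl chain carries the low number, which a saturated pentyl chain or a shorter alkyne such as prop-1-yn-1-yl could separate. Also open, from the compounds shown here alone, is how a simple amine on this carbon would read.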